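A few compounds are considered here, and "the series" means these few. Any claim that something is new, unique, unknown or untested is made for them only; others in the source may bear on it.

Compound 1, `COc1cc(N)c(Cl)cc1NC(=O)C1CCN(C2CCCC2)CC1`, gives in a functional assay on the whole organism for antagonist activity, with Mus musculus as the target (a higher number here means that more compound is needed for the effect, a lower number that less compound is needed), the value > 10 mg/kg, which is a limit of the assay.
Compound 2, `COc1cc(N)c(Cl)cc1NC(=O)C1CCN(Cc2ccccc2Cl)CC1`, gives in this assay the value > 4 mg/kg, again only a limit.

Compound 2 thus stands only at a limit (the limit of > 4 mg/kg in this assay, at which 1 of the 2 values shown sits), with no number of its own. Compound 3, `CCCN1CCC(C(=O)Nc2cc(Cl)c(N)cc2OC)CC1`, differs from compound 2 by ethyl in place of 2-chlorophenyl on a saturated chain carbon bound to an amine nitrogen in a ring. Among the measured compounds shown here, the one measured step, a step that the two limits leave unreadable from compound 1 to compound 2, also exchanges the group on an amine nitrogen in a ring, but two limits leave its size unreadable, so no size or direction can be expected with confidence in this assay. Compound 3 is therefore estimated to give 10 mg/kg, between 3 mg/kg and 40 mg/kg. That expectation corresponds to a step that the limit leaves unreadable from compound 2 to compound 3.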

Compound 3, dose for half-maximal effect: > 10 mg/kg
Compound 3 gave a limit, no number; the forecaster's own chance of this, stated with the estimate: 70%; the middle value lies on the limit itself.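

In this assay compound 3 gives only a limit, as do compound 1 and compound 2, so no step among these compounds can be read. On these data alone, whether cyclopentyl, 2-chlorobenzyl or propyl on the amine nitrogen in a ring changes the dose needed stays open.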